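The compounds below may be only part of what the source reports. "The series", "measured", "known", "first", "only" and "open" are said of these compounds alone.

Of the compounds shown here, three that share one core have been measured in a functional assay on cells (Cancer cell lines, Homo sapiens) for cytotoxicity, read by sulforhodamine B assay, with a stated time of 48 h; a higher number here means a weaker inhibitor of growth, a lower number a stronger inhibitor of growth. In that test compound 1 `O=C1N=C(N2N=C(c3ccccc3)CC2c2ccccc2O)S/C1=C1/C(=O)Nc2ccccc21` gives 2130 nM. Compound 2 `COc1ccc(C2=NN(C3=NC(=O)/C(=C4\C(=O)Nc5ccccc54)S3)C(c3ccc(OC)cc3)C2)cc1`, which carries a methoxy group on each of its two phenyl rings, gives 43900 nM. Compound 3 `O=C1N=C(N2N=C(c3ccccc3)CC2c2ccc(Cl)cc2)S/C1=C1/C(=O)Nc2ccccc21` gives 190 nM, the lowest of the three numbers, with compound 1 nearest to it and compound 2 furthest from it. Among the measured compounds shown here, the only comparison that changes a single site is an 11-fold lower number from compound 1 to compound 3 (1.05 log units; beyond the scatter), showing that the group on the saturated ring carbon can move the number a great deal.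

Compound 4 `COc1ccc(C2=NN(C3=NC(=O)/C(=C4\C(=O)Nc5ccccc54)S3)C(c3ccc(Cl)cc3)C2)cc1` has not yet been measured. It differs from compound 3 by methoxy in place of hydrogen on an aromatic carbon. For the measured compounds named here, no measured pair isolates this change: compound 2 carries the same methoxy together with a second one and lacks the chloro group, so its high number cannot be credited to the methoxy alone. Still, compound 2 is the only carrier of a methoxy group here, and its value stands far above the others. The step of a 2.6-fold higher number from compound 3 to compound 4 (0.42 log units; beyond the scatter) is therefore expected to be a moderate weakening, one that may or may not pass the scatter. Compound 4 is estimated at 500 nM, with a plausible range from 120 nM to 3000 nM.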

Compound 4, concentration for 50% growth inhibition: 77500 nM
For compound 4 the middle estimate is 160-fold (2.19 log units) below the measured one; measured number outside the range, above it.
By their numbers in this assay, from the lowest: compound 3; then compound 1; then compounds 2 and 4 (each within the scatter of the next).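

In this assay, a single methoxy group on an aromatic carbon, para to a large group, turns phenyl into 4-methoxyphenyl and gives a 410-fold higher number from compound 3 to compound 4 (2.61 log units; beyond the scatter), so this one change alone is enough to take away nearly all the growth inhibition seen with compound 3. The earlier compounds shown here could not show this, since compound 2 differs from compound 3 in two places, whereas this pair isolates the methoxy group and places a large part of the high number of compound 2 on this position. Once 4-methoxyphenyl is present, exchanging the group on the other ring makes no readable difference, with a 1.8-fold higher number from compound 2 to compound 4 (0.25 log units; within the scatter), so the chloro group that accompanies the low number of compound 3 does not preserve growth inhibition here. Nothing in the available data explains why this methoxy group has so large an effect.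

The compounds shown leave open whether the sharp change belongs to methoxy itself or would also appear with another group at this place, such as fluorine, a hydroxyl or an amine. They also leave open whether the same methoxy step would appear with the 2-hydroxyphenyl group of compound 1 on the saturated ring carbon.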